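Notes on compound 3, an analogue of compound 1

The source may report more compounds than this note shows. Statements on the series, on what has been measured and on what is new or still open speak of the compounds shown alone.

compound 1 `COc1ccc(/C=C(\C(=O)c2ccc(Br)cc2)S(=O)(=O)c2ccc(Br)cc2)cc1`: 25000 nM
compound 2 `COc1ccc(/C=C(\C(=O)c2ccc(Br)cc2)S(=O)(=O)c2ccc(C)cc2)cc1`: 1000 nM

In a functional assay on DU-145 cells (Homo sapiens) for inhibition, read by trypan blue exclusion, with a stated time of 96 h (a higher number here means a weaker inhibitor of growth, a lower number a stronger inhibitor of growth), compound 1 gives 25000 nM, the higher of the two numbers measured. Among the compounds with values here, compound 2 gives 1000 nM, and the only measured step, a 25-fold lower number from compound 1 to compound 2 (1.40 log units; beyond the scatter), is methyl in place of bromo on an aromatic carbon. Compound 3 `O=C(/C(=C\c1ccc(Br)c([N+](=O)[O-])c1)S(=O)(=O)c1ccc(Br)cc1)c1ccc(Br)cc1` differs from compound 1 as follows: 4-bromo-3-nitrophenyl in place of 4-methoxyphenyl on a double-bonded chain carbon bound to a double-bonded chain carbon. Within the data shown here, this change falls on the double-bonded chain carbon, not on the aromatic carbon altered between compound 1 and compound 2, so the one measured step does not bear on it. No step beyond the scatter is therefore expected, no change at the digits printed from compound 1 to compound 3 (within the scatter). For compound 3 the estimate in this assay is 25000 nM, within 6000 nM to 100000 nM.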

Compound 3, concentration for 50% growth inhibition: 10000 nM
Estimate against measurement, compound 3: 2.5-fold (0.40 log units) above; the measured number falls inside the stated range.
By their numbers in this assay, from the lowest: compound 2; then compound 3; then compound 1.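

In this assay, the place on a double-bonded chain carbon bound to a double-bonded chain carbon proves responsive: 4-bromo-3-nitrophenyl in place of 4-methoxyphenyl gives a 2.5-fold lower number from compound 1 to compound 3 (0.40 log units; beyond the scatter). This makes it a second place on the core of compound 1 where a change moves the number, alongside the aromatic carbon changed in compound 2. Nothing available accounts for this step.

The entering group brings bromo and nitro together, and the compounds shown do not separate them. Going by these compounds, how an amine or a carboxylic acid at this place would read also stays open.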